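The source may hold more compounds than are shown below. What is called first, only, known or untested is meant among the compounds shown, and "the series" means these compounds.

Measured compounds:
- compound 1 `O=C1NCCN1c1ccc(S(=O)(=O)Nc2ccc(C3CCCCC3)cc2)cc1`: > 1000 nM
- compound 2 `Cc1ccc(NS(=O)(=O)c2ccc(N3CCNC3=O)cc2)cc1`: 610 nM
- compound 3 `CCCCc1ccc(NS(=O)(=O)c2ccc(N3CCNC3=O)cc2)cc1`: 770 nM
Not yet measured: compound 4 `COc1ccccc1NS(=O)(=O)c1ccc(N2CCNC2=O)cc1`.

In a functional assay on MCF7 cells (Homo sapiens) for antiproliferative activity, read by sulforhodamine B assay, with a stated time of 48 h (a lower number here means a stronger inhibitor, a higher number a weaker inhibitor), compound 2 gives 610 nM, the lowest of the two numbers. Compound 3 gives 770 nM, and the step of a 1.3-fold higher number from compound 2 to compound 3 (0.10 log units; within the scatter) lies within the scatter, so the two are not ordered. For compound 1 the value > 1000 nM is a limit of the assay and not a number; compound 1 sits at the limit of > 1000 nM in this assay, at which 1 of the 3 values shown sits. The steps of an at least 1.6-fold lower number from compound 1 to compound 2 (0.21 log units; that floor lies within the scatter) and an at least 1.2-fold lower number from compound 1 to compound 3 (0.11 log units; that floor lies within the scatter) have floors within the scatter.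

The change to compound 4 is 2-methoxyphenyl in place of 4-methylphenyl on a sulfonamide nitrogen. Among the measured compounds shown here, all three measured steps alter the group on the sulfonamide nitrogen, and none of them moved the read-out beyond the scatter; no measured step adds a hydrogen-bond acceptor there. The change to compound 4 is therefore expected to give a 1.1-fold higher number from compound 2 to compound 4 (0.06 log units; within the scatter), a step in no direction beyond the scatter, with some chance of a limit. Compound 4 is estimated at 700 nM, within 300 nM to 2000 nM.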

Compound 4, half-maximal inhibitory concentration: 770 nM
Beside the measured number, compound 4's estimate is 1.1-fold (0.04 log units) below it; the measured number falls inside the stated range.
By their numbers in this assay, from the lowest: compounds 2, 3 and 4 (each within the scatter of the next). At a limit, above all of these: compound 1.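

In this assay, 2-methoxyphenyl in place of 4-methylphenyl on the sulfonamide nitrogen gives a 1.3-fold higher number from compound 2 to compound 4 (0.10 log units; within the scatter). Compound 4 is the only compound shown with a hydrogen-bond acceptor in this group, so this position tolerates that oxygen-bearing group without a shift beyond the scatter, at least against the 4-methylphenyl group of compound 2. Nothing measured here accounts for this result.

The step changes both the substituent and its printed ring number, so it cannot separate the two, and a comparison with 4-methoxyphenyl or 2-methylphenyl would be needed to do so. On these data alone, whether an amine or a carboxylic acid on this phenyl ring would move the number beyond the scatter also remains open.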